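The compounds below may be only part of what the source reports. "The series", "measured", "known", "first", "only" and "open" are said of these compounds alone.

Compound 1 `Nc1nc(N2CCCC2)c2ncn(/C=C3/CC3(CO)CO)c2n1` in an ADME assay on MOLT-3 cells (Homo sapiens) for cytotoxicity, with a stated time of 7 days; on this read-out higher numbers stand for lower toxicity in this test and lower numbers for higher toxicity in this test: "not determined" (no result reported).
Compound 2 `CCOc1nc(N)nc2c1ncn2/C=C1/CC1(CO)CO` in this assay: > 20000 nM, a limit of the assay.
Compound 3 `C=CCOc1nc(N)nc2c1ncn2/C=C1/CC1(CO)CO` in this assay: > 20000 nM, a limit of the assay.

Compound 3 stands only as a limit in this assay, so no single number places it among the others. Compound 2 likewise shows only a limit, and this is all the measured evidence there is: the limit of > 20000 nM in this assay, at which 2 of the 3 values shown sit. Within the data shown here, the single step that connects two measured compounds, a step that the two limits leave unreadable from compound 2 to compound 3, is therefore unreadable in size and direction.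

Compound 4 `CNc1nc(N)nc2c1ncn2/C=C1/CC1(CO)CO` differs from compound 3 in one place: methylamino in place of allyloxy on an aromatic carbon. Among the measured compounds shown here, no measured step involves a change of this kind, and the one step that exists cannot be read. Nothing in the data therefore points to a step beyond the scatter in this assay in either direction; the expectation rests on both measured compounds sitting at the same limit.

Compound 4 is accordingly expected to give about 25000 nM in this assay, with a range from 8000 nM to 100000 nM, and most likely again only a limit. The step this estimate means, a step that the limit leaves unreadable from compound 3 to compound 4, is expected to stay within the usual scatter.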

Compound 4, half-maximal cytotoxic concentration: > 20000 nM
Compound 4 ended at the assay's limit (the forecaster's own chance of this, stated with the estimate: 80%); the middle value does not contradict the limit.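

Compound 4, like compound 2 and compound 3, gives only a limit in this assay, so no new step from either compound to compound 4 can be read, and the evidence remains: the limit of > 20000 nM in this assay, at which 3 of the 4 values shown sit.

The compounds shown leave open whether allyloxy, ethoxy and methylamino on this aromatic carbon differ at all in this assay.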